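The source may hold more compounds than are shown below. What is called first, only, known or untested is meant among the compounds shown, and "the series" means these compounds.

Compound 1 `O=C(Nc1ccccc1)c1cc(Oc2ccc(/C=C/c3ccccn3)cc2)ccn1`: 19100 nM
Compound 2 `O=C(Nc1ccc(Cl)cc1)c1cc(Oc2ccc(/C=C/c3ccccn3)cc2)ccn1`: 16200 nM

In a functional assay on A549 cells (Homo sapiens) for antiproliferative activity, read by CCK-8 assay, with a stated time of 48 h (a lower number here means a stronger inhibitor, a higher number a weaker inhibitor), compound 1 gives 19100 nM, the higher of the two numbers; its nearest neighbour is compound 2 at 16200 nM, and the two lie within the scatter of each other. Compound 3 `O=C(NCc1ccc(F)cc1)c1cc(Oc2ccc(/C=C/c3ccccn3)cc2)ccn1` differs from compound 1 in a single place: 4-fluorobenzyl in place of phenyl on an amide-type nitrogen. Cut one bond further out, the change reads anilino to (4-fluorobenzyl)amino. Among the compounds with values here, the only measured step, a 1.2-fold lower number from compound 1 to compound 2 (0.07 log units; within the scatter), puts a chloro in place of hydrogen on an aromatic carbon and touches neither the amide-type nitrogen nor what hangs from it, so it bears only loosely on the present change: it shows that a small alteration nearby left the number within the scatter. Within the data shown here, no measured step covers the phenyl-to-benzyl switch itself, so no direction beyond the scatter can be expected. Compound 3 is therefore estimated at 15000 nM, with a range of 5000 nM to 45000 nM. The expected step is a 1.3-fold lower number from compound 1 to compound 3 (0.10 log units; within the scatter), with wide uncertainty.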

Compound 3, half-maximal inhibitory concentration: > 100000 nM
Compound 3 gave a limit, no number; the forecaster's own chance of this, stated with the estimate: 10%; middle value at least 6.6-fold (0.82 log units) from the limit.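

Compound 3 gives only a limit in this assay, not a number: the limit of > 100000 nM in this assay, at which 1 of the 3 values shown sits. The step from a phenyl to a 4-fluorobenzyl on the amide-type nitrogen is an at least 5.2-fold higher number from compound 1 to compound 3 (0.71 log units; beyond the scatter), and the step from a 4-chlorophenyl to the same group is an at least 6.1-fold higher number from compound 2 to compound 3 (0.79 log units; beyond the scatter). The earlier step, a 1.2-fold lower number from compound 1 to compound 2 (0.07 log units; within the scatter), showed only that a chloro on the ring left the number within the scatter, whereas these two show that exchanging the whole group on this nitrogen can cost most of the modest activity present.

The change brings the benzyl and the fluorine together, so the compounds shown cannot say which of them matters. A plain benzyl, a 4-fluorophenyl or a longer chain ending in an amine on this nitrogen would be the open cases.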